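Lengthening the ester arm of compound 2

A few compounds are considered here, and "the series" means these few. Any claim that something is new, unique, unknown or untested is made for them only; others in the source may bear on it.

Measured in an ADME assay on L02 cells (Homo sapiens) for cytotoxicity, read by MTT assay; on this read-out higher numbers stand for weaker inhibition and lower numbers for stronger inhibition:
Compound 1 `COc1ccc(/C=C/C(=O)c2ccc(OC)c3c2OC(C)(C)C=C3)cc1OCCO`: > 10000 nM, a limit
Compound 2 `COc1ccc(/C=C/C(=O)c2ccc(OC)c3c2OC(C)(C)C=C3)cc1OC(=O)CCl`: > 10000 nM, a limit

Compound 2 therefore has no exact number, only a limit. The same holds for the whole set so far, which stands at the limit of > 10000 nM in this assay, at which 2 of the 2 values shown sit.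

Compound 3 `COc1ccc(/C=C/C(=O)Oc2cc(/C=C/C(=O)c3ccc(OC)c4c3OC(C)(C)C=C4)ccc2OC)cc1` keeps the shared core and the ester but carries a much larger group: 2-(4-methoxyphenyl)ethenyl in place of chloromethyl on a carbonyl carbon. In short, 2-(4-methoxyphenyl)ethenyl stands in place of chloromethyl on a carbonyl carbon.

Within the data shown here, the only measured step that bears on this change is a step that the two limits leave unreadable from compound 1 to compound 2, which also altered the group on an oxygen on an aromatic ring. It gives no size that could be carried over, so no step beyond the scatter can be forecast in either direction in this assay. The expectation rests on compound 2, whose reading of > 10000 nM is a limit. The estimated step is a step that the limit leaves unreadable from compound 2 to compound 3, and it is expected to stay unresolved if the assay again returns only a limit. For compound 3 the expected value is 15000 nM, with an estimated range from 6000 nM to 40000 nM.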

Compound 3, half-maximal inhibitory concentration: 18000 nM
Estimate against measurement, compound 3: 1.2-fold (0.08 log units) below, within the range that was stated.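

In this assay, no step can be read from compound 2 or compound 1 to compound 3, because each of those two earlier compounds gives only a limit: the limit of > 10000 nM in this assay, at which 2 of the 3 values shown sit.

The compounds shown leave open whether 2-(4-methoxyphenyl)ethenyl in place of chloromethyl on a carbonyl carbon changes the reading in this assay at all, and in which direction.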